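A few compounds are considered here, and "the series" means these few. Any claim that something is new, unique, unknown or untested is made for them only; others in the source may bear on it.

In an ADME assay on Vero cells (Chlorocebus sabaeus) for cytotoxicity (a higher number here means that more compound is tolerated, a lower number that less compound is tolerated), three compounds have been measured so far, and each of them sits at the top limit of the assay rather than at a number:

Compound 1 `O=C(O)c1cccc(-c2ccc(/C=C3\S/C(=N\c4ccc(Cl)cc4)N(c4ccc(Cl)cc4)C3=O)o2)c1` gives > 200000 nM, a limit of the assay.
Compound 2 `O=C(O)c1cccc(-c2ccc(/C=C3\S/C(=N\c4ccccc4)N(c4ccc(Cl)cc4)C3=O)o2)c1` gives > 200000 nM, a limit of the assay.
Compound 3 `O=C(O)c1cccc(-c2ccc(/C=C3\S/C(=N\c4ccccc4)N(c4ccc(F)cn4)C3=O)s2)c1` gives > 200000 nM, a limit of the assay.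

Compound 2 therefore stands where everything shown stands: at the limit, with no number of its own, and the two further values are limits as well. Within the data shown here, the only step between measured compounds that differ in a single place, a step that the two limits leave unreadable from compound 1 to compound 2, has a size that cannot be read because the limit of > 200000 nM in this assay, at which 3 of the 3 values shown sit, covers both of its ends.

Compound 4 `O=C(O)c1cccc(-c2ccc(/C=C3\S/C(=N\c4ccccc4)N(c4cccnc4Cl)C3=O)o2)c1` has not yet been measured in this assay. It differs from compound 2 by 2-chloropyridin-3-yl in place of 4-chlorophenyl on an amide-type nitrogen in a ring. Among the measured compounds shown here, no measured step of readable size bears on this change; the one step on record is unreadable. For the measured compounds named here, with every value at the limit and no step pointing up or down, the expectation is that compound 4 will again fall at the limit, with no change beyond the scatter. Compound 4 is accordingly expected to give 200000 nM, in a range from 100000 nM to 200000 nM. The estimated step, a number no higher from compound 2 to compound 4 (the limit leaves the size open), is expected to be none beyond the scatter.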

Compound 4, half-maximal cytotoxic concentration: > 200000 nM
Compound 4: only a limit was reported; the forecaster's own chance of this, stated with the estimate: 85%; the middle value sits exactly at the limit.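

Compound 4 lands where compound 2 stands, so the size of the change from compound 2 to compound 4 cannot be read, because both ends are covered by one limit: the limit of > 200000 nM in this assay, at which 4 of the 4 values shown sit.

The compounds shown leave open how much of any of them the cells tolerate in this assay, and whether 2-chloropyridin-3-yl in place of 4-chlorophenyl changes that at all.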